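Swapping Benzyl for 3-Methylphenyl: Expected Effect on Cytotoxicity

The source may report more compounds than this note shows. Statements on the series, on what has been measured and on what is new or still open speak of the compounds shown alone.

Compound 2 `O=C(O)c1cn(C2CC2)c2cc(N3CCN(C(=O)CN4CCN(Cc5ccccc5)CC4)CC3)c(F)cc2c1=O` is the reference point here. In an ADME assay on RAW264.7 cells (Mus musculus) for cytotoxicity, read by MTT assay, with a stated time of 72 h, tested at 50 uM (on this read-out lower numbers stand for less inhibition and higher numbers for more inhibition at the one concentration tested (going by the name of the read-out)), compound 2 gives 15.5%, the lowest of the three numbers shown, although compound 1 `CC(=O)N1CCN(CC(=O)N2CCN(c3cc4c(cc3F)c(=O)c(C(=O)O)cn4C3CC3)CC2)CC1`, which gives 16.2%, lies so close that no order between the two can be claimed. Within the data shown here, compound 3 `O=C(O)c1cn(C2CC2)c2cc(N3CCN(C(=O)CN4CCN(C(c5ccccc5)c5ccccc5)CC4)CC3)c(F)cc2c1=O` gives 25.9% and is the only measured compound clearly apart from compound 2.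

Compound 4 `Cc1cccc(N2CCN(CC(=O)N3CCN(c4cc5c(cc4F)c(=O)c(C(=O)O)cn5C4CC4)CC3)CC2)c1` arises from compound 2 through (3-methylphenyl in place of benzyl on an amine nitrogen in a ring).

Two measured steps inform the expectation. The step of a number 0.7 percentage points lower from compound 1 to compound 2 (within the scatter) shows that exchanging one group on this ring nitrogen for another left the read-out unchanged. The step of a number 10.4 percentage points higher from compound 2 to compound 3 (beyond the scatter) shows that enlarging the group on the carbon attached to that nitrogen produced a modest rise. The change to compound 4 rearranges the same atoms rather than adding any, so the account expects a step of a number 3.5 percentage points higher from compound 2 to compound 4 (within the scatter), not beyond the scatter. Compound 4 is therefore estimated at 19%, within the range 8% to 32%.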

Compound 4, a percentage reported as inhibition, at one concentration (the size of the read-out at that concentration, not a potency): 16.2%
For compound 4 the middle estimate is 2.8 percentage points above the measured one; the measured number falls inside the stated range.
By their numbers in this assay, from the lowest: compounds 2, 1, 4 and 3 (each within the scatter of the next, the first and the last beyond it).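

The replacement of benzyl by 3-methylphenyl on this amine nitrogen in a ring gave a number 0.7 percentage points higher from compound 2 to compound 4 (within the scatter) in this assay and the replacement of acetyl by the same group gave no change at the digits printed from compound 1 to compound 4 (within the scatter) so that compounds 1, 2 and 4 all lie within the scatter of one another. Before compound 4, only the exchange of acetyl for benzyl had been seen at this nitrogen; compound 4 extends that flat result to a group with the same atoms as benzyl, joined differently. Nothing available here explains why the read-out stayed level across these groups.

Going by these compounds, whether an unsubstituted phenyl or a phenyl carrying an amine or a carboxylic acid on this nitrogen would stay within the same scatter remains open. The compounds shown also leave open how a longer chain between this nitrogen and the aromatic ring would read.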